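A few compounds are considered here, and "the series" means these few. Any claim that something is new, unique, unknown or untested is made for them only; others in the source may bear on it.

Working notes on the series in an assay on isolated protein for inhibition of glucose-6-phosphatase catalytic subunit 1 (Homo sapiens), read by inositol phosphate accumulation, with a stated time of 30 min, tested at 100 uM; a lower number here means less inhibition, a higher number more inhibition at the concentration tested (going by the name of the read-out).

Compound 1 `CCOC(=O)C1=CC(c2ccccc2)C2=C(CC(C)(C)CC2=O)N1` is the ethyl ester of the shared core. In this assay compound 1 gives "not active" (no number reported), so no single number stands for it; a second entry of the series is in the same position. Compound 2 `Cc1ccc(C2=CC(c3ccccc3)C3=C(CC(C)(C)CC3=O)N2)cc1` carries an aryl group in place of the ester, and in this assay compound 2 gives "not active" (no number reported). Compound 3 `CC1(C)CC(=O)C2=C(C1)NC(C(=O)O)=CC2c1ccccc1` is the free acid of the same core, and in this assay compound 3 gives 17.1%. Going by the values given here, no step between measured compounds is available, so the three entries can only be read side by side: the one compound with a number, compound 3, sits at the low end of the read-out, and the other two gave no number at all.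

Compound 4 `CCOC(=O)C1=CC(c2ccc(Cl)cc2)C2=C(CC(C)(C)CC2=O)N1` is the next compound in the series. It differs from compound 1 as follows: chloro in place of hydrogen on an aromatic carbon. The phenyl group becomes a 4-chlorophenyl group, with the chloro on an aromatic carbon of a six-membered aromatic ring of carbon only, para to a large group. Nothing in the measured set speaks to this change, and compound 1 itself gave no number, so any movement of the size seen between compound 1 and compound 3 would be hard to read. The expectation for compound 4 is a step in this assay that does not go beyond the scatter, in either direction. Compound 4 is therefore estimated at 6%, within a range of 0% to 22%.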

Compound 4, a percentage reported as inhibition, at one concentration (the size of the read-out at that concentration, not a potency): 11.3%
The estimate for compound 4 lay 5.3 percentage points below the measured number; measured number inside the range.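

Compound 1 gives "not active" (no number reported) and compound 4 gives 11.3%, so no step can be read between compound 1 and compound 4. The compounds shown leave open whether phenyl to 4-chlorophenyl on the shared core moves the read-out at all. No measured evidence bears on this result.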